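The source may report more compounds than this note shows. Statements on the series, on what has been measured and on what is new or still open speak of the compounds shown alone.

Measured compounds:
compound 1 `COc1ccc(C2=C(c3ccccc3)C3(C=CC(=O)C=C3)OC2=O)cc1` — 64000 nM
compound 2 `COc1cc(C2=C(c3ccccc3)C3(C=CC(=O)C=C3)OC2=O)cc(OC)c1OC` — 9730 nM
compound 3 `COc1c(Br)cc(C)cc1C1=C(c2ccccc2)C2(C=CC(=O)C=C2)OC1=O` — 9450 nM

In a functional assay on MDA-MB-231 cells (Homo sapiens) for antiproliferative activity, read by MTT assay, with a stated time of 48 h (on this read-out lower numbers stand for stronger inhibition and higher numbers for weaker inhibition), compound 1 gives 64000 nM, the highest number of the three. Compound 2 gives 9730 nM and compound 3 gives 9450 nM, each a lower number than compound 1 by a margin beyond the scatter. Compound 4 `O=C1C=CC2(C=C1)OC(=O)C=C2c1ccccc1` has not been measured in this assay. It differs from compound 1 by hydrogen in place of 4-methoxyphenyl on a double-bonded ring carbon. For the measured compounds named here, no measured pair shows this change, so its size is unknown; the shared core is kept and the phenyl group stays. Compound 4 is expected to give a number around 110000 nM, with a range of 35000 nM to 350000 nM. The step from a 1.7-fold higher number from compound 1 to compound 4 (0.24 log units; within the scatter) is estimated as a modest rise in number, though none beyond the scatter would not surprise.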

Compound 4, half-maximal inhibitory concentration: 15900 nM
Compound 4: middle estimate off by 6.9-fold (0.84 log units), on the high side, outside the stated range (below it).
By their numbers in this assay, from the lowest: compounds 3, 2 and 4 (each within the scatter of the next); then compound 1.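

Hydrogen in place of 4-methoxyphenyl on the double-bonded ring carbon gives a 4.0-fold lower number from compound 1 to compound 4 (0.60 log units; beyond the scatter) in this assay, the first step read at this position. The 4-methoxyphenyl group is therefore not required for antiproliferative activity on this core, and here its loss lowers the number. Nothing measured explains this step.

On these data alone, only hydrogen and 4-methoxyphenyl are compared at this carbon, so the shape of the trend remains open. A methyl group, an unsubstituted phenyl or an amine there could still move the number either way.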